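Swapping thiophen-2-yl for (naphthalen-1-yl)methyl

The compounds below may be only part of what the source reports. "The series", "measured", "known", "first", "only" and "open" are said of these compounds alone.

In a functional assay on HL-60 cells (Homo sapiens) for inhibition, read by CCK-8 assay, with a stated time of 48 h (a higher number here means a weaker inhibitor, a lower number a stronger inhibitor), compound 1 `COc1ccc(S(=O)(=O)Oc2ccccc2/C=C(\C#N)C(=O)Nc2nnc(-c3cccs3)s2)cc1` gives 5230 nM and shares the stronger end of this small set with compound 2 `COc1ccc(S(=O)(=O)Nc2cccc(/C=C(\C#N)C(=O)Nc3nnc(-c4cccs4)s3)c2)cc1` at 8370 nM within the usual scatter of each other. Compound 3 `COc1ccc(Cc2nnc(NC(=O)/C(C#N)=C/c3ccccc3OS(=O)(=O)c3ccc(Cl)cc3)s2)cc1` gives 11400 nM and is weaker than compound 1 beyond that scatter.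

Compound 4 `COc1ccc(S(=O)(=O)Oc2ccccc2/C=C(\C#N)C(=O)Nc2nnc(Cc3cccc4ccccc34)s2)cc1` carries (naphthalen-1-yl)methyl in place of thiophen-2-yl on an aromatic carbon and otherwise matches compound 1. Among the measured compounds shown here, no measured pair shows this change alone. Compound 3 at 11400 nM also bears a larger group at that place but differs elsewhere too, so it is only a loose guide. In this assay a small loss is expected, an estimated 1.5-fold higher number from compound 1 to compound 4 (0.18 log units; within the scatter) that may stay inside the scatter. Compound 4 is estimated at 8000 nM with a range from 2500 nM to 22000 nM in this measurement.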

Compound 4, half-maximal inhibitory concentration: 4700 nM
Estimate against measurement, compound 4: 1.7-fold (0.23 log units) above; measured number inside the range.
By their numbers in this assay, from the lowest: compounds 4, 1, 2 and 3 (each within the scatter of the next, the first and the last beyond it).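

Among the compounds shown here, replacing thiophen-2-yl with (naphthalen-1-yl)methyl gives a 1.1-fold lower number from compound 1 to compound 4 (0.05 log units; within the scatter) in this assay, the first step here that changes this place alone. This aromatic carbon of the shared core therefore takes a group of 11 heavy atoms, with two six-membered aromatic rings and no ring sulfur, without a shift in the number beyond the usual scatter. No measurement shown accounts for this. On these data alone, whether an amine or a carboxylic acid at this place would also hold the number remains open.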